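This account rests on a few compounds, and the source may have more. Where it says the series, first, only, none or still open, it means among the compounds named here.

- compound 1 `COc1cc2c(Nc3cccc(Br)c3)ncnc2cc1OCCCCn1ccnc1[N+](=O)[O-]` gives 1430 nM
- compound 2 `COc1cc2c(Nc3cccc(Br)c3)ncnc2cc1OCCCCCn1ccnc1[N+](=O)[O-]` gives 2540 nM

Both values come from a functional assay on HT-29 cells (Homo sapiens) for inhibition, read by sulforhodamine B assay, with a stated time of 72 h (a lower number here means a stronger inhibitor, a higher number a weaker inhibitor), and compound 2 stands within the scatter of compound 1. Compound 3 `COc1cc2c(Nc3cccc(Br)c3)ncnc2cc1OCCCCCCn1ccnc1[N+](=O)[O-]` differs from compound 2 as follows: (2-nitro-1H-imidazol-1-yl)methyl in place of 2-nitro-1H-imidazol-1-yl on a saturated chain carbon, five bonds along the chain from an oxygen on an aromatic ring. Among the measured compounds shown here, the only measured step bearing on this is the same change made four bonds along the chain from an oxygen on an aromatic ring: a 1.8-fold higher number from compound 1 to compound 2 (0.25 log units; within the scatter). That single step lies within the scatter and sets no trend. The estimated step is a 1.4-fold higher number from compound 2 to compound 3 (0.14 log units; within the scatter), leaning toward a higher number, with nothing expected beyond the scatter. For compound 3 the expected value is 3500 nM, with an estimated range of 1500 nM to 8000 nM.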

Compound 3, half-maximal inhibitory concentration: 4300 nM
Compound 3: middle estimate off by 1.2-fold (0.09 log units), on the low side; measured number inside the range.
By their numbers in this assay, from the lowest: compounds 1, 2 and 3 (each within the scatter of the next, the first and the last beyond it).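

Extending the chain by one more unit at this place gives a 1.7-fold higher number from compound 2 to compound 3 (0.23 log units; within the scatter), a step that alone stays within the scatter in this assay. Among the compounds shown here, the wider change, 2-(2-nitro-1H-imidazol-1-yl)ethyl in place of 2-nitro-1H-imidazol-1-yl, gives a 3.0-fold higher number from compound 1 to compound 3 (0.48 log units; beyond the scatter), the first step beyond the scatter and a modest one, so chain length at this place does register once two units are added.

Open, as far as these compounds go, is how a shorter chain, or an amine in place of the 2-nitro-1H-imidazol-1-yl group, would read here. Nothing available accounts for the chain-length result.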